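The compounds below may be only part of what the source reports. "The series", "measured", "known", "first", "only" and "open" are said of these compounds alone.

Measured compounds in a functional assay on RAW264.7 cells (Mus musculus) for inhibition, read by Griess assay, with stated times of 2 h and 24 h; a lower number here means a stronger inhibitor, a higher number a weaker inhibitor:
Compound 1 `COc1ccc([C@@H]2CC(=O)c3c(O)cc(OCc4cn(Cc5ccccc5Cl)nn4)cc3O2)cc1O` gives 6140 nM.
Compound 2 `COc1ccc([C@@H]2CC(=O)c3c(O)cc(OCc4cn(Cc5ccc(C)cc5)nn4)cc3O2)cc1O` gives 16800 nM.
Compound 3 `COc1ccc([C@@H]2C/C(=N\O)c3c(O)cc(OCc4cn(C5CCCC5)nn4)cc3O2)cc1O` gives 6880 nM.

Compound 2 stands at the highest number of the three in this assay; compound 3 sits a little below it, and compound 1 lowest, both beyond the scatter. Compound 4 `COc1ccc([C@@H]2CC(=O)c3c(O)cc(OCc4cn(Cc5ccccc5)nn4)cc3O2)cc1O` is not yet measured. Its difference from compound 2 is hydrogen in place of methyl on an aromatic carbon: the methyl on the aromatic carbon, para to a large group, is removed, so the 4-methylbenzyl becomes a benzyl.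

Within the data shown here, only one measured step touches this region: a 2.7-fold higher number from compound 1 to compound 2 (0.44 log units; beyond the scatter), which swapped a 2-chlorophenyl for a 4-methylphenyl and weakened inhibition modestly. Among the measured compounds shown here, no measured pair isolates the methyl alone, so its contribution cannot be read directly; the benzyl of compound 4 sits between the two measured aryl groups. The expectation is therefore a modest drop in the number, a 1.7-fold lower number from compound 2 to compound 4 (0.23 log units; within the scatter), toward compound 1 but likely not reaching it.

Compound 4 is estimated at 10000 nM in this assay, with a range from 4000 nM to 25000 nM.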

Compound 4, half-maximal inhibitory concentration: 11000 nM
For compound 4 the middle estimate is 1.1-fold (0.04 log units) below the measured one, within the range that was stated.
By their numbers in this assay, from the lowest: compounds 1, 3, 4 and 2 (each within the scatter of the next, the first and the last beyond it).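

Among these compounds, the benzyl of compound 4 separates the two substituents for the first time: hydrogen in place of methyl on the aromatic carbon gives a 1.5-fold lower number from compound 2 to compound 4 (0.18 log units; within the scatter), and hydrogen in place of chloro gives a 1.8-fold higher number from compound 1 to compound 4 (0.25 log units; within the scatter). Neither single change leaves the scatter in this assay, so neither the methyl nor the chloro can be said on its own to shift the number, and the gap beyond the scatter appears only when compound 1 and compound 2 are set against each other. No measurement at hand offers an explanation for these small steps.

As far as these compounds go, it remains open whether a larger group on the benzyl, such as a methoxy, a trifluoromethyl or a carboxylic acid, would shift the number beyond the scatter. The same question stands for an amine there.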